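The source may hold more compounds than are shown below. What is called first, only, known or untested is meant among the compounds shown, and "the series" means these compounds.

Three compounds have so far been run through a functional assay on the whole organism (strain Wistar Albino) for inhibition, with Rattus norvegicus as the target, read by paw edema, with a stated time of 4 h, at a dose of 20 mg/kg; on this read-out lower numbers stand for less inhibition and higher numbers for more inhibition at the one dose given (going by the name of the read-out). Compound 1, `Cc1occc1-c1nnc2sc(-c3ccnc(Cl)c3)nn12`, gives 27.1% in this assay. Compound 2, `COc1ccc2[nH]c(C)c(Cc3nn4c(-c5ccoc5C)nnc4s3)c2c1`, gives 31.2% in this assay. Compound 3, `COc1ccc(Cl)c(-c2nnc3n2NC(c2ccc([N+](=O)[O-])o2)S3)c1`, gives 24.2% in this assay, which is the lowest of the three numbers; however, its gap to compound 1 and its gap to compound 2 both lie within the usual scatter of repeated measurements, so the three values cannot be told apart with confidence.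

Going by the values given here, no two of the measured compounds differ in a single place, so no measured step can guide what a single change should do. Compound 4, `COc1ccc(Cl)c(-c2nnc3n2NC(c2cccn2C)S3)c1`, has not yet been measured. It differs from compound 3 as follows: 1-methyl-1H-pyrrol-2-yl in place of 5-nitrofuran-2-yl on a saturated ring carbon.

Among the compounds with values here, with no comparable step in hand, the account rests on the values themselves. All three measured values sit close together, and a step from compound 3 to compound 4 beyond the scatter is not expected in either direction. The change from compound 3 to compound 4 is therefore estimated as a number 0.2 percentage points lower from compound 3 to compound 4 (within the scatter) in this assay. Compound 4 is expected to give about 24% in this assay, with a likely range from 12% to 38%.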

Compound 4, a percentage reported as inhibition, in the whole organism at one dose (the size of the read-out at that dose, not a potency): 20.7%
Estimate against measurement, compound 4: 3.3 percentage points above; the range from low to high includes it.
By their numbers in this assay, from the lowest: compounds 4, 3, 1 and 2 (each within the scatter of the next, the first and the last beyond it).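

In this assay, going by these compounds alone, the exchange on a saturated ring carbon, next to the ring nitrogen and next to the ring sulfur, gives the first measured step at this position, a number 3.5 percentage points lower from compound 3 to compound 4 (within the scatter). The step is a sizeable change on paper: 5-nitrofuran-2-yl, with 8 heavy atoms, 3 hydrogen-bond acceptors and 1 double bond outside aromatic rings, gives way to 1-methyl-1H-pyrrol-2-yl, with 6 heavy atoms, 1 hydrogen-bond acceptor and no such double bond, while a five-membered aromatic ring with 1 hetero atom remains in both, and still the two compounds cannot be told apart in this read-out. No measurement is available that bears on why this exchange leaves the value within the scatter.

Within the data shown here, this single step concerns only two aromatic groups on one core, so it leaves open whether a group of another kind on the same carbon, such as an amine, a carboxylic acid or a longer alkyl chain, would move the value beyond the scatter. It also leaves open whether the same exchange would read alike on a different core.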